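This account rests on a few compounds, and the source may have more. Where it says the series, first, only, none or still open, it means among the compounds named here.

Measured compounds:
Compound 1, `Cc1ccccc1Nc1nc(Nc2ccc(N3CCNCC3)cn2)ncc1Cl`, in an ADME assay on L02 cells (Homo sapiens) for inhibition, read by CCK-8 assay, with a stated time of 48 h (on this read-out higher numbers stand for weaker inhibition of growth and lower numbers for stronger inhibition of growth), compound 1 gives 1850 nM.
Compound 2, `CN1CCN(c2ccc(Nc3ncc(Cl)c(NCc4ccc(C(F)(F)F)cc4)n3)nc2)CC1`, in this assay compound 2 gives 26200 nM.

Compound 2 has the highest of the two numbers, so of the two it inhibits growth of these liver cells least; compound 1 sits far below it, beyond the usual scatter. Compound 3, `COc1ccc(Nc2nc(Nc3ccc(N4CCN(C)CC4)cn3)ncc2Cl)cc1`, has not yet been measured. It differs from compound 2 in one place: 4-methoxyphenyl in place of 4-(trifluoromethyl)benzyl on a nitrogen on an aromatic ring. With that exchange compound 3 takes on the same kind of link, an aromatic ring set directly on the nitrogen, that compound 1 carries, while keeping the rest of compound 2. Compound 3 is therefore expected to land closer to compound 1 than compound 2 does, which means a step downward, beyond the scatter, of about a 7.5-fold lower number from compound 2 to compound 3 (0.87 log units; beyond the scatter). The estimate for compound 3 is 3500 nM, with a likely range from 1000 nM to 12000 nM.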

Compound 3, concentration for 50% growth inhibition: 3150 nM
Compound 3: middle estimate off by 1.1-fold (0.05 log units), on the high side, and the stated range covers the measured number.
By their numbers in this assay, from the lowest: compounds 1 and 3 (each within the scatter of the next); then compound 2.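

For the compounds shown here, the pair compound 2 and compound 3 gives the first reading of a single change on this nitrogen: in this assay, 4-methoxyphenyl in place of 4-(trifluoromethyl)benzyl gives an 8.3-fold lower number from compound 2 to compound 3 (0.92 log units; beyond the scatter). So the group on this nitrogen can by itself shift growth inhibition of these liver cells, in this case towards stronger inhibition. The exchange alters two things at once, the benzyl link and the trifluoromethyl-to-methoxy swap, and no measurement here explains the shift.

The compounds shown leave open which of those two alterations accounts for the step. A 4-(trifluoromethyl)phenyl group or a 4-methoxybenzyl group on the same nitrogen would separate them, since each alters only one.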